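Fluoro added to the bromophenyl arm: cytotoxicity notes

The source may hold more compounds than are shown below. What is called first, only, known or untested is meant among the compounds shown, and "the series" means these compounds.

Measured so far:
compound 1, `O=S(=O)(Nc1cccc(CO)c1)c1ccc(-c2ccc3[nH]ccc3c2)cc1`: in a functional assay on J774 cells (Mus musculus) for cytotoxicity, read by resazurin assay, with a stated time of 72 h (a lower number here means a stronger inhibitor, a higher number a weaker inhibitor), compound 1 gives > 5000 nM, a limit of the assay rather than a number.
compound 2, `O=S(=O)(Nc1cccc(CO)c1)c1ccc(-c2ccc(Br)cc2)cc1`: in this assay compound 2 gives 2500 nM.

Going by the values given here, compound 2 holds the only number in this assay; the other value shown is a limit. Among the compounds with values here, the one measured step, an at least 2.0-fold lower number from compound 1 to compound 2 (0.30 log units; that floor lies within the scatter), is bounded by the limit of > 5000 nM in this assay, at which 1 of the 2 values shown sits, and its floor lies within the scatter, so it sets no firm size.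

Compound 3, `O=S(=O)(Nc1cccc(CO)c1)c1ccc(-c2ccc(Br)cc2F)cc1`, differs from compound 2 by fluoro in place of hydrogen on an aromatic carbon. Within the data shown here, no measured step adds a fluoro to an existing arm; the step from compound 1 to compound 2 replaces the whole aryl and bears on this change only loosely. Among the measured compounds shown here, with no step of this kind on record, no change beyond the scatter is expected in this assay, and the estimated step is a 1.1-fold higher number from compound 2 to compound 3 (0.05 log units; within the scatter). Compound 3 is therefore expected near 2800 nM, within 1200 nM to 6500 nM.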

Compound 3, half-maximal inhibitory concentration: 1000 nM
Compound 3: the middle estimate sits 2.8-fold (0.45 log units) above what was measured; measured number outside the range, below it.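

Fluoro in place of hydrogen on this aromatic carbon, ortho to a large group and meta to the bromo group, is the first single-atom change in the series, and in this assay it gives a 2.5-fold lower number from compound 2 to compound 3 (0.40 log units; beyond the scatter). This position on the 4-bromophenyl arm therefore registers in the read-out, which the earlier replacement of the whole aryl could not show. The wider step, an at least 5.0-fold lower number from compound 1 to compound 3 (0.69 log units; beyond the scatter), sets a floor and no firm size: the limit of > 5000 nM in this assay, at which 1 of the 3 values shown sits.

One fluoro at one carbon does not show whether a chloro, a methyl, a methoxy or an amine at the same place would move the number in the same direction. On these data alone, whether the fluoro step carries over to the 1H-indol-5-yl arm, or to an arm without the bromo group, also remains open.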